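The source may report more compounds than this note shows. Statements on the series, on what has been measured and on what is new or still open speak of the compounds shown alone.

Three compounds share one core and differ in the group on an oxygen on a saturated carbon: compound 1 (`COCO[C@@H]1/C=C(\C)CC[C@]2([C@@](C)(O)C(=O)SCc3oc(=O)oc3C)CC(=O)N([C@H](C)c3nc(cs3)/C=C/C=C/C1=O)[S+]2[O-]`), compound 2 (`COC1(O[C@@H]2/C=C(\C)CC[C@]3([C@@](C)(O)C(=O)SCc4oc(=O)oc4C)CC(=O)N([C@H](C)c4nc(cs4)/C=C/C=C/C2=O)[S+]3[O-])CCOCC1`) and compound 3 (`C/C1=C\[C@@H](O[C@@H]2CCCCO2)C(=O)/C=C/C=C/c2csc(n2)[C@@H](C)N2C(=O)C[C@@]([C@@](C)(O)C(=O)SCc3oc(=O)oc3C)(CC1)[S+]2[O-]`). In a functional assay on HeLa cells (Homo sapiens) for antiproliferative activity (a higher number here means a weaker inhibitor, a lower number a stronger inhibitor), compound 1 gives 0.17 nM, compound 2 gives 1.4 nM and compound 3 gives 0.67 nM, so compound 3 has the second highest number of the three.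

Compound 4 (`C/C1=C\[C@@H](O)C(=O)/C=C/C=C/c2csc(n2)[C@@H](C)N2C(=O)C[C@@]([C@@](C)(O)C(=O)SCc3oc(=O)oc3C)(CC1)[S+]2[O-]`) removes that group from compound 3 altogether: hydrogen in place of oxan-2-yl on an oxygen on a saturated carbon. This puts hydrogen in place of oxan-2-yl on the oxygen and leaves a hydroxy.

Among the compounds with values here, three measured steps bear on this change, each swapping one group on that oxygen for another. They are a 3.9-fold higher number from compound 1 to compound 3 (0.60 log units; beyond the scatter), an 8.2-fold higher number from compound 1 to compound 2 (0.92 log units; beyond the scatter) and a 2.1-fold lower number from compound 2 to compound 3 (0.32 log units; beyond the scatter). All are modest, though beyond the scatter. None of them reaches a hydroxy, so they indicate how far this assay has moved with changes at this oxygen, but they do not settle the direction.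

A modest step is therefore expected, and a lower number is only a tentative expectation, resting on compound 1 at 0.17 nM as the lowest of the three. The expected step is a 1.7-fold lower number from compound 3 to compound 4 (0.22 log units; within the scatter). The estimated value for compound 4 is 0.4 nM, with an expected range of 0.1 nM to 1.8 nM.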

Compound 4, half-maximal inhibitory concentration: 4.6 nM
For compound 4 the middle estimate is 12-fold (1.06 log units) below the measured one; measured number outside the range, above it.
By their numbers in this assay, from the lowest: compound 1; then compound 3; then compound 2; then compound 4.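

In this assay, within the data shown here, the hydroxy of compound 4 gives the highest number of the set, with a 6.9-fold higher number from compound 3 to compound 4 (0.84 log units; beyond the scatter) and a 3.3-fold higher number from compound 2 to compound 4 (0.52 log units; beyond the scatter) and then a 27-fold higher number from compound 1 to compound 4 (1.43 log units; beyond the scatter) as the only large step among those at this oxygen. The earlier compounds shown here showed only that methoxymethyl, oxan-2-yl and 4-methoxyoxan-4-yl differ from one another, whereas compound 4 shows that each of these three groups gives a lower number than hydrogen on an oxygen on a saturated carbon, with no compound among the four going against that order. The data given here offer nothing that accounts for this gap between the hydroxy and the three substituted oxygens.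

The compounds shown leave open whether something as small as a methyl or an acetyl group on this oxygen would be enough to bring the number down toward that of compound 1 or whether methoxymethyl holds its place at the low end only against these two ring-bearing groups. They also leave open whether the same order would hold for a longer chain such as a methoxyethoxymethyl group on this oxygen.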